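The compounds below may be only part of what the source reports. "The series", "measured", "known", "first", "only" and "open" are said of these compounds alone.

Three compounds share one core and differ only in the group on the saturated chain carbon bound to an aromatic carbon. Compound 1 `Cc1nc2c(OCc3ccccc3)cccn2c1CCC#N` gives 40% in a functional assay on the whole organism with Rattus norvegicus as the target, with a stated time of 4 h, at a dose of 40 mg/kg by the intraperitoneal route; on this read-out lower numbers stand for less inhibition and higher numbers for more inhibition at the one dose given (going by the name of the read-out). Compound 2 `CCOCc1c(C)nc2c(OCc3ccccc3)cccn12` gives 84%, and the step of a number 44 percentage points higher from compound 1 to compound 2 (beyond the scatter) is the largest rise among the three. Compound 3 `Cc1nc2c(OCc3ccccc3)cccn2c1COC(=O)C(C)(C)C` gives 48% and stands second highest of the three numbers. Its nearest number is that of compound 1, and a number 8 percentage points higher from compound 1 to compound 3 (within the scatter) lies within the scatter. Its furthest number is that of compound 2, and a number 36 percentage points lower from compound 2 to compound 3 (beyond the scatter) lies beyond the scatter.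

Compound 4 `Cc1nc2c(OCc3ccccc3)cccn2c1COC(=O)c1cccnc1` keeps the ((tert-butyl)carbonyl)oxy linkage of compound 3 in the sense that only the group on the carbonyl carbon is exchanged: pyridin-3-yl in place of tert-butyl on a carbonyl carbon. Going by the values given here, no measured step alters that part of the molecule. Among the compounds with values here, the one step that touches the carbonyl, a number 36 percentage points lower from compound 2 to compound 3 (beyond the scatter), introduces the (tert-butyl)carbonyl in place of an ethyl on the oxygen and so does not describe an exchange of one group on a carbonyl carbon for another. With the carbonyl retained, the author expects compound 4 to stay near compound 3, a step of a number 2 percentage points higher from compound 3 to compound 4 (within the scatter) expected to fall within the scatter. The estimate for compound 4 is 50%, ranging from 25% to 75%.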

Compound 4, a percentage reported as inhibition, in the whole organism at one dose (the size of the read-out at that dose, not a potency): 87%
Estimate against measurement, compound 4: 37 percentage points below; measured number outside the range, above it.
By their numbers in this assay, from the lowest: compounds 1 and 3 (each within the scatter of the next); then compounds 2 and 4 (each within the scatter of the next).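

Exchanging tert-butyl for pyridin-3-yl on the carbonyl carbon, with the rest of the molecule unchanged, gives a number 39 percentage points higher from compound 3 to compound 4 (beyond the scatter) in this assay, so a carbonyl on this oxygen does not by itself go with a low number, as the step from compound 2 to compound 3 alone might have suggested. The group on the carbonyl carbon matters here: a number 3 percentage points higher from compound 2 to compound 4 (within the scatter) leaves the (pyridin-3-yl)carbonyl and the ethyl on this oxygen indistinguishable, while a number 47 percentage points higher from compound 1 to compound 4 (beyond the scatter) sets compound 4 well clear of the cyanomethyl compound. Nothing available explains why the pyridin-3-yl group differs so much from tert-butyl at this place.

The compounds shown leave open whether the rise belongs to the aromatic ring or to its nitrogen, a question that a phenyl group on the carbonyl carbon would address, and whether the place of that nitrogen matters, as pyridin-2-yl or pyridin-4-yl would show. Going by these compounds alone, they also leave open whether the oxygen itself is needed, since no compound here carries an amide nitrogen in its place with the pyridin-3-yl carbonyl kept.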